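Expected Tolerance of Compound 4 from Three Measured Analogues

This account rests on a few compounds, and the source may have more. Where it says the series, first, only, none or still open, it means among the compounds named here.

Measured in an ADME assay on HeLa cells (Homo sapiens) for cytotoxicity, read by MTT assay, with a stated time of 72 h; a lower number here means that less compound is tolerated, a higher number that more compound is tolerated:
Compound 1, `C(=N/c1sc2c(c1-c1nc3ccccc3s1)CCCC2)\c1ccccc1`: 333 ug/mL
Compound 2, `Clc1ccccc1/C=N/c1sc2c(c1-c1nc3ccccc3s1)CCCC2`: 407 ug/mL
Compound 3, `O=[N+]([O-])c1ccccc1/C=N/c1sc2c(c1-c1nc3ccccc3s1)CCCC2`: 369 ug/mL

Compound 3 stands second highest of the three numbers. Its nearest neighbour is compound 2, with a 1.1-fold lower number from compound 2 to compound 3 (0.04 log units; within the scatter); its furthest is compound 1, with a 1.1-fold higher number from compound 1 to compound 3 (0.04 log units; within the scatter). The remaining step, a 1.2-fold higher number from compound 1 to compound 2 (0.09 log units; within the scatter), is likewise within the scatter, so the three compounds are indistinguishable in this assay.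

Compound 4, `C(=C/c1ccccc1)\C=N\c1sc2c(c1-c1nc3ccccc3s1)CCCC2`, has not yet been measured. It differs from compound 3 by 2-phenylethenyl in place of 2-nitrophenyl on a carbon with a double bond to nitrogen. None of the three measured steps concerns this kind of change: they exchange hydrogen, chloro and nitro on an aromatic carbon, while here the whole 2-nitrophenyl group is replaced by 2-phenylethenyl. Among the measured compounds shown here, with all measured steps within the scatter and no step that bears directly on the change, compound 4 is expected to show a step of a 1.1-fold lower number from compound 3 to compound 4 (0.02 log units; within the scatter), that is, none beyond the scatter. Compound 4 is therefore estimated at 350 ug/mL, within a range of 200 ug/mL to 600 ug/mL.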

Compound 4, half-maximal cytotoxic concentration: 389 ug/mL
For compound 4 the middle estimate is 1.1-fold (0.05 log units) below the measured one, and the stated range covers the measured number.
By their numbers in this assay, from the lowest: compounds 1, 3, 4 and 2 (each within the scatter of the next).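

In this assay, the place on a carbon with a double bond to nitrogen accepts 2-phenylethenyl with no step beyond the scatter, whether it replaces 2-nitrophenyl (a 1.1-fold higher number from compound 3 to compound 4 (0.02 log units; within the scatter)), 2-chlorophenyl (a 1.0-fold lower number from compound 2 to compound 4 (0.02 log units; within the scatter)) or phenyl (a 1.2-fold higher number from compound 1 to compound 4 (0.07 log units; within the scatter)). The earlier compounds shown here exchanged only hydrogen, chloro and nitro on an aromatic carbon, whereas compound 4 shows that the number also holds when the whole group is replaced by one made of carbon only, with a double bond outside the aromatic ring. No supporting data are available to explain this result.

On these data alone, it remains open whether the number would also hold with a group lacking an aromatic ring at this place, such as an amine, a carboxylic acid or a longer chain. With all four compounds within the scatter of one another, these compounds do not identify any group at this place that shifts the number in this assay at all.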